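Hydroxamate series: pyridin-2-yl in place of 5-methylfuran-2-yl

The source may hold more compounds than are shown below. What is called first, only, known or untested is meant among the compounds shown, and "the series" means these compounds.

In an assay on Sf9 cells for inhibition of protein deacetylase HDAC6 (Homo sapiens), read by fluorescence, with a stated time of 40 min, tested at 100 nM (on this read-out lower numbers stand for less inhibition and higher numbers for more inhibition at the one concentration tested (going by the name of the read-out)), compound 1 `Cc1ccc(-c2nc(CNc3ccc(C(=O)NO)cc3)n(-c3ccccc3)n2)o1` gives 60.7% and so stands highest of the two numbers on hand. The other measured member, compound 2 `CCc1ccc(-n2nc(-c3ccccc3)nc2CNc2ccc(C(=O)NO)cc2)cc1`, gives 38.3% in this assay, a gap that lies beyond the usual scatter. Among the measured compounds shown here, no pair of measured compounds differs in a single place, so the effect of one change on the shared core cannot be read from the measured set.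

Compound 3 `O=C(NO)c1ccc(NCc2nc(-c3ccccn3)nn2-c2ccccc2)cc1` differs from compound 1 at a single position: pyridin-2-yl in place of 5-methylfuran-2-yl on an aromatic carbon. Both groups bring the same count of heavy atoms, no hydrogen-bond donor and one hydrogen-bond acceptor, and no net charge.

For the measured compounds named here, with no single-place step to rest on, a step of moderate size is expected, most likely downward or none beyond the scatter. The expected step from compound 1 to compound 3 in this assay is a number 12.7 percentage points lower from compound 1 to compound 3 (beyond the scatter). Compound 3 is estimated at 48% in this assay, with a range from 25% to 70%.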

Compound 3, a percentage reported as inhibition, at one concentration (the size of the read-out at that concentration, not a potency): 58.6%
Compound 3: middle estimate off by 10.6 percentage points, on the low side; the measured number falls inside the stated range.
By their numbers in this assay, from the lowest: compound 2; then compounds 3 and 1 (each within the scatter of the next).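

In this assay, among the compounds shown here, pyridin-2-yl in place of 5-methylfuran-2-yl gives a number 2.1 percentage points lower from compound 1 to compound 3 (within the scatter) and provides the only single-place step so far. At this position, on an aromatic carbon of a five-membered aromatic ring with 3 nitrogen and between two ring nitrogen atoms, a six-membered aromatic ring with 1 hetero atom and a five-membered aromatic ring with 1 hetero atom read alike at the one concentration tested, so this exchange of ring size and hetero atom leaves the read-out within the scatter. No measurement on hand speaks to why the two groups read alike.

From the compounds shown here alone, both groups are aromatic rings, so it remains open whether the position would hold the read-out with a non-aromatic group such as a morpholine, a primary amine, a carboxylic acid or a plain methyl. For the compounds shown here, also open is what a change at the ring atom that bears a phenyl group would do on its own, since no single-place step covers that site.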